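The source may hold more compounds than are shown below. What is called first, only, known or untested is meant among the compounds shown, and "the series" means these compounds.

Measured so far in an assay on membranes from brain for binding affinity to Lysophosphatidylserine lipase ABHD12 (Mus musculus), read by fluorescence, with a stated time of 20 min; a lower number here means a stronger inhibitor, a higher number a weaker inhibitor:
Compound 1 `FC(F)(F)Oc1ccc(Oc2ccnc(N3CCC(NC(=S)Nc4cccnc4)CC3)c2)cc1` gives 410 nM.
Compound 2 `COc1ccnc(N2CCC(NC(=S)Nc3cccnc3)CC2)c1` reaches only the limit of the assay, > 5000 nM.
Compound 3 `FC(F)(F)c1ccnc(N2CCC(NC(=S)Nc3cccnc3)CC2)c1` gives 640 nM.

Compound 3 holds the higher of the two numbers shown, yet its gap to compound 1 lies within the scatter, so the two cannot be ranked. Compound 4 `S=C(Nc1cccnc1)NC1CCN(c2cc(OC3CCCCC3)ccn2)CC1` differs from compound 3 by one change: cyclohexyloxy in place of trifluoromethyl on an aromatic carbon. For the measured compounds named here, two measured steps bear on this position. an at least 12-fold higher number from compound 1 to compound 2 (1.08 log units; beyond the scatter), and an at least 7.8-fold lower number from compound 2 to compound 3 (0.89 log units; beyond the scatter); both show methoxy at this place sitting at the limit of > 5000 nM in this assay, at which 1 of the 3 values shown sits, while the other groups give numbers. Cyclohexyloxy, like the ether group of compound 1, is far from methoxy. For compound 4, the step of a 1.3-fold lower number from compound 3 to compound 4 (0.11 log units; within the scatter) is expected to stay within the scatter. Compound 4 is estimated at 500 nM, between 150 nM and 2000 nM.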

Compound 4, half-maximal inhibitory concentration: 3400 nM
For compound 4 the middle estimate is 6.8-fold (0.83 log units) below the measured one; the measured number lies above the stated range.
By their numbers in this assay, from the lowest: compounds 1 and 3 (each within the scatter of the next); then compound 4. At a limit, above all of these: compound 2.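

The group on the oxygen decides the outcome here, since an ether at this position does not by itself match the earlier numbers. Cyclohexyl in place of 4-(trifluoromethoxy)phenyl gives a clear loss (an 8.3-fold higher number from compound 1 to compound 4 (0.92 log units; beyond the scatter)), and cyclohexyloxy in place of trifluoromethyl gives another (a 5.3-fold higher number from compound 3 to compound 4 (0.73 log units; beyond the scatter)). The third step starts from a limit and gives only a floor (an at least 1.4-fold lower number from compound 2 to compound 4 (0.16 log units; that floor lies within the scatter)): the limit of > 5000 nM in this assay, at which 1 of the 4 values shown sits.

As far as these compounds go, it remains open whether a plain phenyl on the oxygen would keep the lower number of compound 1. From the compounds shown here alone, it is equally open how an amine or a longer chain would behave at this position.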